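Aryl variation at the saturated carbon: cytotoxicity notes

The source may report more compounds than this note shows. Statements on the series, on what has been measured and on what is new or still open speak of the compounds shown alone.

Measured so far:
compound 1 `COc1cc(N2C(N)=C(C#N)C(c3ccc(Cl)cc3Cl)C3=C2CC(C)(C)CC3=O)cc(OC)c1OC`: 100%
compound 2 `COc1ccc(C2C(C#N)=C(N)N(c3cc(OC)c(OC)c(OC)c3)C3=C2C(=O)CC(C)(C)C3)cc1`: 15%

Going by the values given here, in a functional assay on Ehrlich cells (Mus musculus) for cytotoxicity, tested at 100 ug/mL (on this read-out lower numbers stand for a weaker effect and higher numbers for a stronger effect at the one concentration tested), compound 2 gives the lowest of the two numbers, with compound 1 the only neighbour. Among the compounds with values here, the one measured step, a number 85 percentage points lower from compound 1 to compound 2 (beyond the scatter), is large. Compound 3 `COc1cc(N2C(N)=C(C#N)C(c3ccccc3)C3=C2CC(C)(C)CC3=O)cc(OC)c1OC` differs from compound 2 by hydrogen in place of methoxy on an aromatic carbon. Within the data shown here, no measured step touches the methoxy itself, so the large step to compound 2 only shows that this aryl position matters. A moderate recovery is expected, a number 15 percentage points higher from compound 2 to compound 3 (beyond the scatter), with wide uncertainty. Compound 3 is estimated at 30%, between 5% and 75%.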

Compound 3, a percentage reported as activity, at one concentration (the size of the read-out at that concentration, not a potency): 10%
For compound 3 the middle estimate is 20 percentage points above the measured one, within the range that was stated.
By their numbers in this assay, from the lowest: compounds 3 and 2 (each within the scatter of the next); then compound 1.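

In this assay, 4-methoxyphenyl and phenyl at this saturated carbon cannot be told apart, with a number 5 percentage points lower from compound 2 to compound 3 (within the scatter). The step of a number 90 percentage points lower from compound 1 to compound 3 (beyond the scatter) shows that the methoxy is not what separates compound 2 from compound 1; among these three compounds, only the one with 2,4-dichlorophenyl stands apart. No measurement at hand offers an explanation for this.

The compounds shown leave open whether both chlorines are needed or a single chlorine on the phenyl ring would give a similar number. Going by these compounds, what a fluorine, an amine or a carboxylic acid on that ring would give also remains open.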